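Chloro to fluoro swap across two related cores

A few compounds are considered here, and "the series" means these few. Any claim that something is new, unique, unknown or untested is made for them only; others in the source may bear on it.

Four compounds carry the same atoms, joined differently. Compound 1 `COc1cc(-c2ncnn2-c2ccc(F)cc2)cc(OC)c1OC` and compound 2 `COc1cc(-c2ncnn2-c2ccc(Cl)cc2)cc(OC)c1OC` bear a 4-fluorophenyl and a 4-chlorophenyl on one core; compound 3 `COc1cc(-n2ncnc2-c2cccc(Cl)c2)cc(OC)c1OC` and the unmeasured compound 4 `COc1cc(-n2ncnc2-c2cccc(F)c2)cc(OC)c1OC` bear a 3-chlorophenyl and a 3-fluorophenyl on the other. How the core of compound 2 differs from the core of compound 3 is not broken down here.

In a functional assay on HeLa cells (Homo sapiens) for antiproliferative activity, read by MTT assay, with a stated time of 72 h (a higher number here means a weaker inhibitor, a lower number a stronger inhibitor), compound 1 gives > 10000 nM, which is a limit of the assay and not a number. In this assay compound 2 gives > 10000 nM, again a limit. The change fluoro in place of chloro on an aromatic carbon therefore yields a step that the two limits leave unreadable from compound 2 to compound 1. In this assay compound 3 gives > 10000 nM, once more a limit. All that the measured set shows is the limit of > 10000 nM in this assay, at which 3 of the 3 values shown sit.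

The change fluoro in place of chloro on an aromatic carbon is the same kind of change as that made from compound 2 to compound 1, not the same: there the halogen sits para to a large group, here meta to a large group. Because (the limit of > 10000 nM in this assay, at which 3 of the 3 values shown sit), there is no readable step to carry over, and compound 4 is expected to remain at the limit rather than below it. For compound 4 the expected step is a step that the limit leaves unreadable from compound 3 to compound 4. Compound 4 is expected to give about 15000 nM in this assay, within a range from 5000 nM to 50000 nM, most probably reported only as a limit.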

Compound 4, half-maximal inhibitory concentration: > 10000 nM
Compound 4 ended at the assay's limit; the forecaster's own chance of this, stated with the estimate: 85%; the middle value lies beyond the limit too.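

In this assay compound 4 gives > 10000 nM, a limit and not a number. Compound 3 also sits at a limit, so no step from compound 3 to compound 4 can be read: the limit of > 10000 nM in this assay, at which 4 of the 4 values shown sit.

The compounds shown leave open whether the halogen, its position or the core changes antiproliferative activity at all, as none of them gives a readable value.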